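The source may report more compounds than this note shows. Statements on the series, on what has been measured and on what is new or still open speak of the compounds shown alone.

Compound 2 `CCC1CCC(c2nc(C(F)(F)F)ccc2CNC(=O)[C@@H](C)c2ccc(NS(C)(=O)=O)c(F)c2)CC1` gives 0.2 nM in an assay on CHO cells for antagonist activity at transient receptor potential cation channel subfamily V member 1 (Homo sapiens), read by FLIPR and calcium flux; a lower number here means a stronger inhibitor, a higher number a weaker inhibitor. That is the lowest of the three numbers measured. Nearest to it is compound 3 `CCC1CCC(c2nc(C(F)(F)F)ccc2CNC(=O)C(C)c2ccc(NS(C)(=O)=O)c(F)c2)CC1`, which gives 0.3 nM; furthest is compound 1 `Cc1nc(C(F)(F)F)ccc1CNC(=O)C(C)c1ccc(NS(C)(=O)=O)c(F)c1`, which gives 387 nM. Two steps connect these three. The step of a 1300-fold lower number from compound 1 to compound 3 (3.11 log units; beyond the scatter) shows that what sits on this aromatic carbon of the shared core sets the number almost entirely. The step of a 1.5-fold higher number from compound 2 to compound 3 (0.18 log units; within the scatter) is small, and it is small because the fact that one of compounds 2 and 3 is drawn with a defined configuration and the other without, at the place where they differ is the only difference between them.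

Compound 4 `C[C@H](C(=O)NCc1ccc(C(F)(F)F)nc1C1CC2CCC1C2)c1ccc(NS(C)(=O)=O)c(F)c1` changes the same place once more: a group of 7 heavy atoms (7 carbon; 2 five-membered non-aromatic rings of carbon only) in place of a group of 8 heavy atoms (8 carbon; one six-membered non-aromatic ring of carbon only), on an aromatic carbon. The step from compound 1 to compound 3 bears on it, since it concerns the same position, and it was large; but it replaced a single carbon with a ring, whereas here one saturated carbon ring gives way to another of nearly the same size. The expected step is therefore modest, a 2.5-fold higher number from compound 2 to compound 4 (0.40 log units; beyond the scatter). Compound 4 is expected to give 0.5 nM. For compound 4 the expected range runs from 0.1 nM to 3 nM.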

Compound 4, inhibition constant: 0.8 nM
Estimate against measurement, compound 4: 1.6-fold (0.20 log units) below; the range from low to high includes it.
By their numbers in this assay, from the lowest: compounds 2 and 3 (each within the scatter of the next); then compound 4; then compound 1.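

For the compounds shown here, compound 1 and compound 3 showed only that replacing a methyl group with a ring at this carbon, next to the ring nitrogen, matters greatly: a 1300-fold lower number from compound 1 to compound 3 (3.11 log units; beyond the scatter). The new result compares two large saturated carbon groups at the same carbon, and in this assay the exchange of 4-ethylcyclohexyl for the group with two five-membered non-aromatic rings gives a 4.0-fold higher number from compound 2 to compound 4 (0.60 log units; beyond the scatter), a real but far smaller change. With compound 4 at 0.8 nM, this position therefore accepts more than one large saturated carbon group with the number staying low, although the choice between them still has a measurable effect, and nothing available explains that effect, as the only note at hand concerns drawn configuration and not this exchange.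

All the groups shown at this carbon contain carbon only, so it remains open how a group containing nitrogen or oxygen, such as a piperidine or a morpholine, would compare. Also open, going by these compounds, is where groups of intermediate size, such as a cyclopropyl ring or a longer chain like n-butyl, would fall between the methyl group and the larger rings.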